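Chain on the ring amide nitrogen: from sec-butyl to dimethylaminoethyl

This account rests on a few compounds, and the source may have more. Where it says the series, first, only, none or still open, it means among the compounds named here.

Measured so far in a functional assay on SW-620 cells (Homo sapiens) for inhibition; a higher number here means a weaker inhibitor, a lower number a stronger inhibitor:
- compound 1 `CCN1C(=O)NC2(CSC3=C2C(=O)c2ccccc2C3=O)C1=O`: 203 nM
- compound 2 `CCCCN1C(=O)NC2(CSC3=C2C(=O)c2ccccc2C3=O)C1=O`: 740 nM
- compound 3 `CCC(C)N1C(=O)NC2(CSC3=C2C(=O)c2ccccc2C3=O)C1=O`: 562 nM

Compound 3 gives the second highest of the three numbers. Its nearest neighbour is compound 2, and the gap a 1.3-fold lower number from compound 2 to compound 3 (0.12 log units; within the scatter) lies within the scatter, so the two cannot be ordered. The furthest step is a 2.8-fold higher number from compound 1 to compound 3 (0.44 log units; beyond the scatter), a modest rise beyond the scatter.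

The next compound is compound 4 `CN(C)CCN1C(=O)NC2(CSC3=C2C(=O)c2ccccc2C3=O)C1=O`. The change from compound 3 is 2-(dimethylamino)ethyl in place of sec-butyl on an amide-type nitrogen in a ring.

For the measured compounds named here, two steps bear on it. Enlarging the ethyl of compound 1 to butyl gave a 3.6-fold higher number from compound 1 to compound 2 (0.56 log units; beyond the scatter), and to sec-butyl gave a 2.8-fold higher number from compound 1 to compound 3 (0.44 log units; beyond the scatter); both show that growing the chain beyond ethyl weakens inhibition modestly. The comparison a 1.3-fold lower number from compound 2 to compound 3 (0.12 log units; within the scatter) shows the shape of the chain did not matter within the scatter. Going by the values given here, the entering group is of similar size to the leaving one; no measured compound carries a nitrogen in this chain, so nothing tells how the added acceptor will read. The expectation is therefore for no step beyond the scatter, and compound 4 is estimated at 500 nM with a range of 150 nM to 1600 nM, an expected step of a 1.1-fold lower number from compound 3 to compound 4 (0.05 log units; within the scatter).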

Compound 4, half-maximal inhibitory concentration: 57 nM
Estimate against measurement, compound 4: 8.8-fold (0.94 log units) above; the measured number lies below the stated range.
By their numbers in this assay, from the lowest: compound 4; then compound 1; then compounds 3 and 2 (each within the scatter of the next).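

In this assay, for the compounds shown here, the chain on the amide-type nitrogen in a ring proves far more sensitive to its make-up than the earlier compounds suggested: 2-(dimethylamino)ethyl in place of sec-butyl gives a 9.9-fold lower number from compound 3 to compound 4 (0.99 log units; beyond the scatter), and dimethylamino in place of the terminal ethyl of the butyl chain gives a 13-fold lower number from compound 2 to compound 4 (1.11 log units; beyond the scatter), so chain length alone does not set the higher numbers of compound 2 and compound 3. The third step, a 3.6-fold lower number from compound 1 to compound 4 (0.55 log units; beyond the scatter), makes compound 4 the exception to the earlier reading that growing the chain beyond ethyl weakens inhibition, and its steps to all three other compounds lie beyond the scatter, leaving it the strongest inhibitor of the four. No measurement at hand accounts for the gain.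

Still open, from the compounds shown here alone, is whether the step follows the chain nitrogen itself or the way it is held, which a 3-(dimethylamino)propyl chain, a 2-(diethylamino)ethyl chain or a 2-hydroxyethyl chain would help to separate. Also open, going by these compounds, is how a morpholine or a carboxylic acid carried on the same chain would read.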